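The source may report more compounds than this note shows. Statements on the series, on what has been measured and on what is new or still open speak of the compounds shown alone.

Working notes on the series. The compounds are compound 1 `O=C(Cn1ccccc1=O)Nc1cc2ccccc2[nH]1`, compound 2 `COC(=O)c1ccc2ccc(C(=O)c3ccccc3)c-2cc1`, compound 3 `c1ccc2cc(CN3CCCCC3)ccc2c1` and the still unmeasured compound 4 `Cn1c(NC(=O)Cn2ccccc2=O)cc2ccccc21`. In a physicochemical assay for lipophilicity, read by HPLC, measured as octanol-water partition, at pH 11 (a higher number here means a more lipophilic compound, a lower number a more polar compound), compound 1 gives 1, the lowest of the two numbers recorded; the nearest number is that of compound 2, which gives 4.7, a gap beyond the scatter. For compound 3 the read-out in this assay is a limit of the assay, > 5.5, namely (the limit of > 5.5 in this assay, at which 1 of the 3 values shown sits). Compound 4 differs from compound 1 by methyl in place of hydrogen on an aromatic nitrogen. For the measured compounds named here, no step between two measured compounds in this assay is available for comparison. The step is expected to be modest and upward, a number 0.70 log units higher from compound 1 to compound 4 (beyond the scatter). Compound 4 is expected to give 1.7 in this assay, within 1.2 to 2.3.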

Compound 4, distribution coefficient: 1.5
Beside the measured number, compound 4's estimate is 0.20 log units above it; the range from low to high includes it.
By their numbers in this assay, from the lowest: compound 1; then compound 4; then compound 2. At a limit, above all of these: compound 3.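

In this assay, for the compounds shown here, methyl in place of hydrogen on an aromatic nitrogen gives the first step that can be read, a number 0.50 log units higher from compound 1 to compound 4 (beyond the scatter), so a change of one heavy atom at this position shifts the read-out by a modest amount. No measurement shown gives a cause for this step.

From the compounds shown here alone, whether ethyl, a longer chain or a chain ending in a carboxylic acid on the same nitrogen would give a step of another size stays open. Going by these compounds, it is also open whether methyl on the amide nitrogen would give a similar step.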